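Acetamido to 2,5-dimethylpyrrolyl: cytotoxicity expectation

This account rests on a few compounds, and the source may have more. Where it says the series, first, only, none or still open, it means among the compounds named here.

Compound 1 `Cc1ccc(C)n1-c1ccc(C(=O)N/N=C/c2ccc(N(C)C)cc2)cc1` belongs to the series but has no result in an ADME assay on A549 cells (Homo sapiens) for cytotoxicity, read by MTT assay, with a stated time of 72 h; on this read-out higher numbers stand for weaker inhibition and lower numbers for stronger inhibition: for compound 1 the entry reads "not determined" (no result reported). Among the compounds with values here, compound 2 `CC(=O)NNC(=O)c1ccc(-n2c(C)ccc2C)cc1` is the only compound with a number: in this assay compound 2 gives 180000 nM, a weak effect. Compound 3 `Cc1ccc(C)n1NC(=O)c1ccc(-n2c(C)ccc2C)cc1` differs from compound 2 by 2,5-dimethyl-1H-pyrrol-1-yl in place of acetamido on an amide-type nitrogen. Within the data shown here, no step between measured compounds is available to calibrate this change, so its size rests on expectation alone. A modest move toward stronger inhibition is expected, the step estimated at a 1.5-fold lower number from compound 2 to compound 3 (0.18 log units; within the scatter), possibly not beyond the scatter. Compound 3 is expected to give 120000 nM in this assay, with a range of 40000 nM to 350000 nM.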

Compound 3, half-maximal inhibitory concentration: 225000 nM
Beside the measured number, compound 3's estimate is 1.9-fold (0.27 log units) below it; measured number inside the range.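

In this assay, this amide-type nitrogen now has its first readable step, a 1.3-fold higher number from compound 2 to compound 3 (0.10 log units; within the scatter), when 2,5-dimethyl-1H-pyrrol-1-yl replaces acetamido. The two compounds cannot be told apart on this read-out, so placing a five-membered aromatic ring here in place of the open acetamido group gives no detectable difference. Nothing available accounts for this result.

On these data alone, whether an amine or a longer acyl chain such as butanoyl on the same nitrogen would give a step beyond the scatter remains open. With a single step, no trend can be drawn for this position.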